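Benzyl replacement of the branched amine substituent in compound 3

This account rests on a few compounds, and the source may have more. Where it says the series, first, only, none or still open, it means among the compounds named here.

In an assay on HEK293 cells for inhibition of SCN8A/SCN1B (Homo sapiens), read by patch clamp, with a stated time of 20 min (a higher number here means a weaker inhibitor, a lower number a stronger inhibitor), compound 1 `C[C@H](Nc1ccc(S(=O)(=O)Nc2nccs2)cc1Cl)c1ccccc1` gives 130 nM, compound 2 `C[C@H](Nc1cc(F)c(S(=O)(=O)Nc2nccs2)cc1Cl)c1ccc(F)cc1` gives 230 nM, and compound 3 `C[C@H](Nc1cc(F)c(S(=O)(=O)Nc2cscn2)cc1Cl)c1ccccc1F` gives 410 nM. Compound 3 holds the highest of the three numbers: compound 2 sits within the scatter of it, while compound 1 lies beyond the scatter with the lower number. Compound 4 `O=S(=O)(Nc1cscn1)c1cc(Cl)c(NCc2cc(F)ccc2F)cc1F` differs from compound 3 in one place: 2,5-difluorobenzyl in place of 1-(2-fluorophenyl)ethyl on a nitrogen on an aromatic ring. Within the data shown here, no measured pair shows this change, so its size in this assay cannot be read from the series. Losing the defined stereocentre is judged more likely to give a higher number than a lower one, by a step that may exceed the scatter. Compound 4 is therefore expected to give 800 nM, with a range from 300 nM to 2500 nM. The expected step is a 2.0-fold higher number from compound 3 to compound 4 (0.29 log units; within the scatter).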

Compound 4, half-maximal inhibitory concentration: 450 nM
Beside the measured number, compound 4's estimate is 1.8-fold (0.25 log units) above it; the range from low to high includes it.
By their numbers in this assay, from the lowest: compounds 1, 2, 3 and 4 (each within the scatter of the next, the first and the last beyond it).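

In this assay, 2,5-difluorobenzyl in place of 1-(2-fluorophenyl)ethyl on the nitrogen gives a 1.1-fold higher number from compound 3 to compound 4 (0.04 log units; within the scatter), so this position accepts a group with no defined stereocentre without a step beyond the scatter. The stereocentre is therefore not needed here to keep a number in this range. Nothing available explains this result.

The step joins two changes, the lost stereocentre and the second fluorine, and the compounds shown do not separate them. As far as these compounds go, how unsubstituted benzyl or a longer chain such as phenethyl would read on this nitrogen remains open.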